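Oxazole to Thiazole in a Cytotoxicity Series

The compounds below may be only part of what the source reports. "The series", "measured", "known", "first", "only" and "open" are said of these compounds alone.

Compound 1 `CCCCOS(=O)(=O)/C=C/c1ccc(OCCc2nc(-c3ccccc3)oc2C)cc1` — > 100000 nM
Compound 2 `CCOS(=O)(=O)/C=C/c1ccc(OCc2ccccc2)cc1OCCc1nc(-c2ccccc2)oc1C` — > 100000 nM
Compound 3 `CCCCOS(=O)(=O)/C=C/c1ccc(OCCc2csc(-c3ccccc3)n2)cc1` — > 100000 nM

Of the compounds shown here, three have been tested in an ADME assay on COS-7 cells (Chlorocebus aethiops) for cytotoxicity, read by MTT assay, with a stated time of 48 h; a lower number here means a stronger inhibitor, a higher number a weaker inhibitor. Compound 1 reaches only a limit of the assay, > 100000 nM. Compound 3 likewise stops at a limit, > 100000 nM. Compound 2, the starting point for the step considered here, also sits at a limit, > 100000 nM. No number is known for any of them, and so compound 2 cannot be placed above or below the other two; all that can be said is that every value shown is a limit, because of the limit of > 100000 nM in this assay, at which 3 of the 3 values shown sit.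

Compound 4 `CCOS(=O)(=O)/C=C/c1ccc(OCc2ccccc2)cc1OCCc1nc(-c2ccccc2)sc1C` is not yet measured. It differs from compound 2 in one place: 5-methyl-2-phenyl-1,3-thiazol-4-yl in place of 5-methyl-2-phenyl-1,3-oxazol-4-yl on a saturated chain carbon, two bonds along the chain from an oxygen on an aromatic ring. Among the measured compounds shown here, no step between two measured compounds is available in this assay, so the size of the change cannot be read from the data. Given that all three measured compounds rest at a limit, the step from compound 2 to compound 4 is expected to be none beyond the scatter, a number no higher from compound 2 to compound 4 (the limit leaves the size open). Compound 4 is therefore estimated at 100000 nM, with a range from 50000 nM to 300000 nM, and most likely reported again as a limit.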

Compound 4, half-maximal inhibitory concentration: > 100000 nM
Compound 4: a limit, no number; the forecaster's own chance of this, stated with the estimate: 85%; the middle value lies on the limit itself.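

No step can be read from compound 2 to compound 4, because neither compound has a number, only a limit: the limit of > 100000 nM in this assay, at which 4 of the 4 values shown sit. The compounds shown leave open whether 5-methyl-2-phenyl-1,3-thiazol-4-yl in place of 5-methyl-2-phenyl-1,3-oxazol-4-yl changes the read-out at all, and how the four compounds would rank in this assay.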